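Bromo to nitro on the aryl ring of compound 3

The compounds below may be only part of what the source reports. "The series", "measured", "known", "first", "only" and "open" are said of these compounds alone.

In a functional assay on HT-29 cells (Homo sapiens) for inhibition, read by sulforhodamine B assay, with a stated time of 48 h (on this read-out higher numbers stand for weaker inhibition of growth and lower numbers for stronger inhibition of growth), compound 3 `CC(C)(C)NCc1c(C(=O)O)nn(-c2ccc(Cl)cc2)c1-c1ccc(Br)cc1` gives > 542000 nM as a limit only. Compound 2 `CC(C)(C)NCc1c(C(=O)O)nn(-c2ccccc2)c1-c1ccc(Br)cc1` gives > 585000 nM as a limit as well. Compound 1 `CCOC(=O)c1nn(-c2ccc(Cl)cc2)c(-c2ccc(Br)cc2)c1CNC(C)(C)C` gives > 511000 nM; > 476000 nM (2 entries) as limits too.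

Compound 4 `CC(C)(C)NCc1c(C(=O)O)nn(-c2ccc(Cl)cc2)c1-c1ccc([N+](=O)[O-])cc1` carries nitro in place of bromo on an aromatic carbon. Within the data shown here, the one measured step, a step that the two limits leave unreadable from compound 2 to compound 3, is a different change and gives no size to carry over. With no readable step behind it, the expected result in this assay is a step that the limit leaves unreadable from compound 3 to compound 4, so no shift beyond the scatter is foreseen. For compound 4 the estimated value is 580000 nM, with an expected range of 300000 nM to 800000 nM, quite possibly again as a limit.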

Compound 4, concentration for 50% growth inhibition: > 583000 nM
Compound 4: only a limit was reported (the forecaster's own chance of this, stated with the estimate: 85%); at least 1.0-fold (0.00 log units) between middle value and limit.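

Compound 3 gives > 542000 nM, a limit. Compound 4 gives > 583000 nM, also a limit, so no step can be read between them. The compounds shown leave open whether any change to the shared core gives a measurable growth inhibition value.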